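A few compounds are considered here, and "the series" means these few. Any claim that something is new, unique, unknown or untested is made for them only; others in the source may bear on it.

Working notes on the ester series.

Compounds 1, 2 and 3 share one core and differ only in the acyl group on the ester carbonyl. Compound 1 `O=C(OCCc1c(-c2ccccc2Cl)c2cc(Cl)ccc2[nH]c1=O)C1CCCC1` gives 46000 nM in an ADME assay on HepG2 2.2.15 cells (Homo sapiens) for cytotoxicity; on this read-out higher numbers stand for lower toxicity in this test and lower numbers for higher toxicity in this test. Compound 2 `O=C(OCCc1c(-c2ccccc2Cl)c2cc(Cl)ccc2[nH]c1=O)c1cccnc1` gives 170000 nM in this assay, and compound 3 `O=C(/C=C/c1ccccc1)OCCc1c(-c2ccccc2Cl)c2cc(Cl)ccc2[nH]c1=O` gives 230000 nM in this assay. Compound 3 carries the highest of the three numbers: its gap to compound 2 is within the scatter, while the steps of a 5.0-fold higher number from compound 1 to compound 3 (0.70 log units; beyond the scatter) and a 3.7-fold higher number from compound 1 to compound 2 (0.57 log units; beyond the scatter) are both beyond it, so the two aromatic-bearing acyl groups sit apart from the cyclopentyl one, and a 1.4-fold higher number from compound 2 to compound 3 (0.13 log units; within the scatter) shows no separation between them.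

Compound 4 `C/C=C/C=C/C(=O)OCCc1c(-c2ccccc2Cl)c2cc(Cl)ccc2[nH]c1=O` is the next member, not yet measured in this assay. The change from compound 3 is prop-1-en-1-yl in place of phenyl on a double-bonded chain carbon bound to a double-bonded chain carbon. Going by the values given here, no measured step exchanges a ring for an open chain within the acyl group, so the only guidance is the narrow spread between compounds 2 and 3 and the modest spread across all three. The expected step is a 1.5-fold lower number from compound 3 to compound 4 (0.19 log units; within the scatter), a small move toward a lower number, within the scatter. Compound 4 is therefore expected to give 150000 nM in this assay, with a range from 60000 nM to 400000 nM.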

Compound 4, half-maximal cytotoxic concentration: 440000 nM
For compound 4 the middle estimate is 2.9-fold (0.47 log units) below the measured one; the whole stated range lies below it.
By their numbers in this assay, from the lowest: compound 1; then compounds 2, 3 and 4 (each within the scatter of the next, the first and the last beyond it).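

In this assay, replacing phenyl with prop-1-en-1-yl on a double-bonded chain carbon bound to a double-bonded chain carbon gives a 1.9-fold higher number from compound 3 to compound 4 (0.28 log units; within the scatter), so among these compounds the phenyl ring can give way to an open chain with no separation from the 2-phenylethenyl ester. The ring-free penta-1,3-dien-1-yl group also stands apart from cyclopentyl, with a 9.6-fold higher number from compound 1 to compound 4 (0.98 log units; beyond the scatter), and from pyridin-3-yl, with a 2.6-fold higher number from compound 2 to compound 4 (0.41 log units; beyond the scatter), so separation from compound 1 does not require an aromatic ring, and compound 2, not separated from compound 3, is separated from compound 4. Nothing available accounts for these differences.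

Still open, on these data alone, is whether a saturated chain such as pentyl on the carbonyl carbon would read with compound 4 or with compound 1. Acyl groups carrying an amine or a carboxylic acid also remain unplaced in this assay.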